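The source may hold more compounds than are shown below. What is called first, only, known or untested is meant among the compounds shown, and "the series" means these compounds.

In a functional assay on NCI-H460 cells (Homo sapiens) for cytotoxicity, read by resazurin assay, with a stated time of 72 h (on this read-out lower numbers stand for stronger inhibition and higher numbers for weaker inhibition), compound 1 `COc1cc(/C=C/C(=O)OCCCCOc2no[n+]([O-])c2S(=O)(=O)c2ccccc2)ccc1O` gives 450 nM. Compound 2 `COc1cc(/C=C/C(=O)OCCCCCCO[N+](=O)[O-])ccc1O` reads > 50000 nM, which is a limit of the assay and not a number. Compound 3 `O=C(/C=C/c1ccc(OCCCCCO[N+](=O)[O-])c(O)c1)OCCCCCO[N+](=O)[O-]` reads > 50000 nM, which is likewise a limit. For the measured compounds named here, compound 2 therefore has no exact position on the scale, and no measured compound differs from another in one place alone.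

Compound 4 `COc1cc(/C=C/C(=O)OCCCCCO[N+](=O)[O-])ccc1O` keeps the ester chain of compound 2 but changes its far end. The difference is nitrooxy in place of (nitrooxy)methyl on a saturated chain carbon, five bonds along the chain from an oxygen next to a carbonyl group.

Going by the values given here, with no measured step to draw on, the expectation for this assay rests on the two limits, those of compound 2 at > 50000 nM and compound 3 at > 50000 nM. No change beyond the usual scatter is expected, and no direction is favoured. The estimated change is a number no higher from compound 2 to compound 4 (the limit leaves the size open). For compound 4 the estimated half-maximal inhibitory concentration is 50000 nM, with an expected range from 15000 nM to 100000 nM, and the assay is expected to report only a limit.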

Compound 4, half-maximal inhibitory concentration: 12300 nM
Estimate against measurement, compound 4: 4.1-fold (0.61 log units) above; measured number outside the range, below it.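

In this assay, the nitrooxy chain on the ester gives a measurable number once it is one carbon shorter, a change of (nitrooxy)methyl to nitrooxy on a saturated chain carbon, five bonds along the chain from an oxygen next to a carbonyl group: this is an at least 4.0-fold lower number from compound 2 to compound 4 (0.60 log units; beyond the scatter). For the compounds shown here, the earlier compounds could not show this, since no two of them differed in one place, so this is the first sign that the far end of the chain is not indifferent in this cell assay, although the values shown offer no cause for the change. Compound 2 gives only a limit and not a number, so the step has a lower bound and its true size stays open: the limit of > 50000 nM in this assay, at which 2 of the 4 values shown sit.

One step of chain length cannot show whether the number keeps falling as the chain shortens further or whether a longer chain always reads at the limit. On these data alone, it also remains open whether an amine or a carboxylic acid in place of the nitrooxy group at the chain end would hold the activity of compound 4, or whether the nitrooxy group is needed at all.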